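Removing a chloro from the urea-bearing aryl ring

This account rests on a few compounds, and the source may have more. Where it says the series, first, only, none or still open, it means among the compounds named here.

Measured compounds:
- compound 1, `O=C(Nc1cccc(-n2cc(-c3ccncc3)c(-c3cc(O)cc(Cl)c3)n2)c1)Nc1ccc(Cl)c(C(F)(F)F)c1`, 97%
- compound 2, `COc1cc(Cl)cc(-c2nn(-c3cccc(NC(=O)Nc4ccc(Cl)c(C(F)(F)F)c4)c3)cc2-c2ccncc2)c1`, 97%

In a functional assay on NCI-H226 cells (Homo sapiens) for inhibition, read by sulforhodamine B assay, with a stated time of 48 h, tested at 0.01 uM (on this read-out higher numbers stand for a weaker effect at the one concentration tested and lower numbers for a stronger effect), compound 1 gives 97%, a value that stands for a weak effect at this concentration. Compound 2 stands level with compound 1 at the digits shown, and the step of no change at the digits printed from compound 1 to compound 2 (within the scatter) lies within the scatter of repeated measurements.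

Compound 3, `COc1cc(Cl)cc(-c2nn(-c3cccc(NC(=O)Nc4cccc(C(F)(F)F)c4)c3)cc2-c2ccncc2)c1`, is not yet measured. It differs from compound 2 by hydrogen in place of chloro on an aromatic carbon. No measured step removes a chloro from this ring, so nothing shown speaks directly to this change. Among the measured compounds shown here, the only step available, no change at the digits printed from compound 1 to compound 2 (within the scatter), shows that a small change elsewhere left the read-out unchanged, and both measured compounds sit close to the weak end of the scale. A step of about a number 1 percentage points lower from compound 2 to compound 3 (within the scatter) is therefore expected, that is, none beyond the scatter.

Compound 3 is estimated at 96%, with a range from 84% to 105%.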

Compound 3, a percentage reported as activity, at one concentration (the size of the read-out at that concentration, not a potency): 95%
Estimate against measurement, compound 3: 1 percentage points above, within the range that was stated.
By their numbers in this assay, from the lowest: compounds 3, 1 and 2 (each within the scatter of the next).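

Removing the chloro turns the 4-chloro-3-(trifluoromethyl)phenyl group into 3-(trifluoromethyl)phenyl, and this is the first change shown on this ring. In this assay, the step is a number 2 percentage points lower from compound 2 to compound 3 (within the scatter), so at the single concentration tested the read-out does not depend measurably on whether this carbon carries chloro or hydrogen, and compound 3 still shows only a weak effect. Nothing measured here offers an explanation for this result.

Still open, going by these compounds, is whether a different group on the same carbon, such as an amine or a carboxylic acid, would shift the read-out beyond the scatter. A single concentration at which the effect is this weak also leaves open whether the chloro matters at concentrations where these compounds act more strongly.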